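The source may report more compounds than this note shows. Statements on the series, on what has been measured and on what is new or still open speak of the compounds shown alone.

Measured compounds:
- compound 1 `O=C(Nc1cc(C(F)(F)F)ccc1Nc1ccc(Br)cc1)c1cccnc1Cl`: 20600 nM
- compound 2 `CCN(CC)c1ccc(C(F)(F)F)cc1NC(=O)c1cccnc1Cl`: 88400 nM
- compound 3 `O=C(Nc1cc(C(F)(F)F)ccc1N1CCCC1)c1cccnc1Cl`: "not active" (no number reported) (no number reported)

In a functional assay on Jurkat cells (Homo sapiens) for cytotoxicity, read by MTT assay, with a stated time of 48 h (a higher number here means a weaker inhibitor, a lower number a stronger inhibitor), compound 1 holds the lowest of the two numbers; the nearest is compound 2, with a 4.3-fold higher number from compound 1 to compound 2 (0.63 log units; beyond the scatter), and compound 3 adds only a report without a number. Compound 4 `O=C(Nc1cc(C(F)(F)F)ccc1Nc1ccc(Br)cc1)c1cccnc1` differs from compound 1 by hydrogen in place of chloro on an aromatic carbon. Among the compounds with values here, no measured step touches this part of the core; the one known step concerns the diethylamino group and offers no guide for a change on the pyridine ring. The expectation for compound 4 is therefore a step of a 1.5-fold higher number from compound 1 to compound 4 (0.16 log units; within the scatter) in this assay, within the scatter, with a wide range. Compound 4 is estimated at 30000 nM, from 8000 nM to 110000 nM.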

Compound 4, half-maximal inhibitory concentration: 17800 nM
Beside the measured number, compound 4's estimate is 1.7-fold (0.23 log units) above it, within the range that was stated.
By their numbers in this assay, from the lowest: compounds 4 and 1 (each within the scatter of the next); then compound 2.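

In this assay, replacing chloro with hydrogen on the aromatic carbon next to the ring nitrogen gives a 1.2-fold lower number from compound 1 to compound 4 (0.06 log units; within the scatter), so 2-chloropyridin-3-yl and pyridin-3-yl cannot be told apart in this pair. The chloro is therefore not required for the cytotoxicity of compound 1 at this level. No measured evidence bears on why this position tolerates the change.

Still open, going by these compounds, is how an amine, a methoxy group or a carboxylic acid at this position would read. Also open, on these data alone, is whether the same exchange gives a similar result with the diethylamino group of compound 2.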